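Chloro for fluoro on the fused ring of compound 3

The compounds below may be only part of what the source reports. "The series", "measured", "known", "first", "only" and "open" are said of these compounds alone.

The shared core carries a tert-butyl isoxazole urea joined to a phenyl that bears a fused bicyclic ring. Compound 1 `CC(C)(C)c1cc(NC(=O)Nc2ccc(-c3cn4ccccc4n3)cc2)no1` gives 3.09 nM in a functional assay on MV4-11 cells (Homo sapiens) for cytotoxicity, read by MTT assay, with a stated time of 72 h; on this read-out higher numbers stand for weaker inhibition and lower numbers for stronger inhibition. Compound 2 `Cc1ccn2cc(-c3ccc(NC(=O)Nc4cc(C(C)(C)C)on4)cc3)nc2c1` gives 0.79 nM in this assay, and the step of a 3.9-fold lower number from compound 1 to compound 2 (0.59 log units; beyond the scatter) is a methyl entering on an aromatic carbon. Compound 3 `CC(C)(C)c1cc(NC(=O)Nc2ccc(-c3cn4cc(F)ccc4n3)cc2)no1` gives 20.9 nM, the highest of the three numbers, with the step of a 6.8-fold higher number from compound 1 to compound 3 (0.83 log units; beyond the scatter) coming from a fluoro entering. Compound 4 `CC(C)(C)c1cc(NC(=O)Nc2ccc(-c3cn4cc(Cl)ccc4n3)cc2)no1` differs from compound 3 by chloro in place of fluoro on an aromatic carbon. Within the data shown here, no measured step swaps one halogen for another at this position; the fluoro step from compound 1 to compound 3 and the methyl step from compound 1 to compound 2 show that single substituents here move the number in either direction beyond the scatter. He therefore expects a step of a 1.7-fold lower number from compound 3 to compound 4 (0.24 log units; within the scatter) for compound 4, modest and uncertain in sign. Compound 4 is estimated at 12 nM, within 3 nM to 50 nM.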

Compound 4, half-maximal inhibitory concentration: 24.8 nM
Compound 4: middle estimate off by 2.1-fold (0.32 log units), on the low side, and the stated range covers the measured number.
By their numbers in this assay, from the lowest: compound 2; then compound 1; then compounds 3 and 4 (each within the scatter of the next).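

In this assay, swapping fluoro for chloro at this position gives a 1.2-fold higher number from compound 3 to compound 4 (0.07 log units; within the scatter) and so leaves compound 3 and compound 4 without any order between them. Measured against the unsubstituted core, the chloro step runs as an 8.0-fold higher number from compound 1 to compound 4 (0.90 log units; beyond the scatter) and points the same way as the fluoro step, which reads a 6.8-fold higher number from compound 1 to compound 3 (0.83 log units; beyond the scatter) and thus shows that the higher number at this position is not confined to fluoro. No measurement shown here accounts for why these two halogens read alike or why either one raises the number over hydrogen.

The compounds shown leave open whether the rise belongs to halogens alone or to any group placed at this position. A bromo, a methoxy or an amine on this same aromatic carbon would help to separate those two readings.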